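A few compounds are considered here, and "the series" means these few. Any claim that something is new, unique, unknown or untested is made for them only; others in the source may bear on it.

In a functional assay on MDA-MB-435 cells (Homo sapiens) for inhibition (on this read-out higher numbers stand for weaker inhibition and lower numbers for stronger inhibition), compound 1 `O=C(/C=C/c1ccc(I)cc1)c1ccc(B(O)O)cc1` gives 10000 nM. For the measured compounds named here, the only other measured compound, compound 2 `O=C(O)COc1ccc(C(=O)/C=C/c2ccc(Cl)c(Cl)c2)cc1`, gives 9000 nM. These two numbers lie within the usual scatter of repeated measurements, so they cannot be told apart, and neither compound can be ranked above the other.

Compound 3 `O=C(O)COc1ccc(C(=O)/C=C/c2ccc(I)cc2)cc1` has not yet been measured. It keeps the core of compound 1, but a carboxymethoxy group replaces the boron-containing group on an aromatic carbon, para to a large group: a group of 5 heavy atoms (2 carbon, 3 oxygen; no ring) in place of a group of 3 heavy atoms (1 boron, 2 oxygen; no ring), on an aromatic carbon.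

Going by the values given here, no two measured compounds differ in one place only, so no measured step shows what this exchange does. Among the compounds with values here, the one guide is compound 2, which carries the same carboxymethoxy group and gives 9000 nM. That is thin evidence, since compound 2 also differs from compound 3 elsewhere. In this assay, the step of no change at the digits printed from compound 1 to compound 3 (within the scatter) is therefore expected to stay within the scatter, with no direction favoured. For compound 3, the estimated value is 10000 nM, with a range from 4000 nM to 25000 nM.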

Compound 3, half-maximal inhibitory concentration: 18000 nM
Compound 3: middle estimate off by 1.8-fold (0.26 log units), on the low side; the measured number falls inside the stated range.
By their numbers in this assay, from the lowest: compounds 2, 1 and 3 (each within the scatter of the next).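

In this assay, for the compounds shown here, the first measured exchange at this position, on an aromatic carbon para to a large group, gives a 1.8-fold higher number from compound 1 to compound 3 (0.26 log units; within the scatter) with the rest of the molecule held the same. Until now, the carboxymethoxy group could be judged only from a compound that also differed elsewhere, whereas this pair isolates the change and shows that the two groups cannot be told apart here, even though the group of 5 heavy atoms has no boron and 1 hydrogen-bond donor, while the group of 3 heavy atoms has boron and 2 hydrogen-bond donors. No measurement shown gives any information on what lies behind this result.

This is a single step, so it cannot show whether every group at this position would read the same, and an amine or a longer chain ending in a carboxylic acid might still move the number beyond the scatter. It also leaves open whether this exchange would behave the same way if the iodine on the other aromatic ring were replaced by another group.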